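Anilino-thiazole series: F508del-CFTR inhibition, step to compound 4

A few compounds are considered here, and "the series" means these few. Any claim that something is new, unique, unknown or untested is made for them only; others in the source may bear on it.

Measured compounds:
compound 1 `COc1ccc(Cl)cc1Nc1nc2c(s1)CCCCc1nc(NC(=O)C(C)(C)C)sc1-2`, 4100 nM
compound 2 `CN(C)c1ccc(Cl)cc1Nc1nc2c(s1)CCCCc1nc(NC(=O)C(C)(C)C)sc1-2`, 2100 nM
compound 3 `Cc1cccnc1Nc1nc2c(s1)CCCCc1nc(NC(=O)C(C)(C)C)sc1-2`, 5200 nM

All three were run in an assay on cells (Epithelial cell) with Cystic fibrosis transmembrane conductance regulator variant F508del (Homo sapiens) as the target, read by fluorescence, with a stated time of 20 h; a higher number here means a weaker inhibitor, a lower number a stronger inhibitor. Compound 3 sits at the high end of the numbers shown: the two steps that end at it are a 1.3-fold higher number from compound 1 to compound 3 (0.10 log units; within the scatter) and a 2.5-fold higher number from compound 2 to compound 3 (0.39 log units; beyond the scatter). Compound 4 `CN(C)c1cccc(Nc2nc3c(s2)CCCCc2nc(NC(=O)C(C)(C)C)sc2-3)c1` carries the change (3-(dimethylamino)phenyl in place of 3-methylpyridin-2-yl on a nitrogen on an aromatic ring). For the measured compounds named here, two measured steps bear on it: a 2.0-fold lower number from compound 1 to compound 2 (0.29 log units; within the scatter), and a 2.5-fold higher number from compound 2 to compound 3 (0.39 log units; beyond the scatter), which runs the opposite way. Neither pair matches a dimethylamino group on a phenyl ring without the chloro group, so the expectation rests on these steps only. A modest lowering is expected, a 1.7-fold lower number from compound 3 to compound 4 (0.24 log units; within the scatter), with compound 4 estimated at 3000 nM (1200 nM to 7500 nM).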

Compound 4, half-maximal inhibitory concentration: 5200 nM
Compound 4: middle estimate off by 1.7-fold (0.24 log units), on the low side; low and high end bracket the measured number.
By their numbers in this assay, from the lowest: compounds 2, 1, 3 and 4 (each within the scatter of the next, the first and the last beyond it).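

In this assay, 3-(dimethylamino)phenyl on this nitrogen gives no change at the digits printed from compound 3 to compound 4 (within the scatter), and against 5-chloro-2-methoxyphenyl it gives a 1.3-fold higher number from compound 1 to compound 4 (0.10 log units; within the scatter), so these aryl groups are not separated. Only a 2.5-fold higher number from compound 2 to compound 4 (0.39 log units; beyond the scatter) lies beyond the scatter, showing that a dimethylamino group alone does not reproduce the lower number seen with 5-chloro-2-(dimethylamino)phenyl. No outside evidence bears on this result.

The compounds shown do not separate the loss of the chloro group from the shift of the dimethylamino group, as both change in that step. From the compounds shown here alone, whether a morpholine in place of dimethylamino would hold the lower number also remains open.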